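The source may hold more compounds than are shown below. What is called first, only, known or untested is meant among the compounds shown, and "the series" means these compounds.

Values in an ADME assay on microsomes from liver (Rattus norvegicus) for metabolic stability, read by mass spectrometry, using NADPH, with a stated time of 10 min; on this read-out lower numbers stand for a less stable compound and higher numbers for a more stable compound:
Compound 1 `COc1cccc(OC)c1-c1c(C2CC2)[nH]c(=O)c(-c2nnc(Cc3ccc(Cl)cc3)o2)c1O`: 51%
Compound 2 `CCCCc1[nH]c(=O)c(-c2nnc(Cc3ccccc3Cl)o2)c(O)c1-c1c(OC)cccc1OC`: 24%
Compound 3 `COCCc1[nH]c(=O)c(-c2nnc(Cc3ccc(Cl)cc3)o2)c(O)c1-c1c(OC)cccc1OC`: 73%

Compound 3 gives the highest of these three numbers. Compound 4 `CCCCc1[nH]c(=O)c(-c2nnc(Cc3ccc(Cl)cc3)o2)c(O)c1-c1c(OC)cccc1OC` has ethyl in place of methoxy on a saturated chain carbon, two bonds along the chain from an aromatic carbon, which turns 2-methoxyethyl into butyl: ethyl in place of methoxy on a saturated chain carbon, two bonds along the chain from an aromatic carbon. Going by the values given here, one measured step touches this chain: a number 22 percentage points higher from compound 1 to compound 3 (beyond the scatter), a modest step, with 2-methoxyethyl in place of cyclopropyl. Compound 4 differs elsewhere from compound 2, which also carries butyl, and compound 2 gives 24%. On that low value, a clear fall in this assay is expected, though probably not all the way. The expected change is a number 35 percentage points lower from compound 3 to compound 4 (beyond the scatter). The estimated value for compound 4 is 38%, within a range of 20% to 58%.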

Compound 4, percent of the compound remaining: 22%
The estimate for compound 4 lay 16 percentage points above the measured number; low and high end bracket the measured number.
By their numbers in this assay, from the lowest: compounds 4 and 2 (each within the scatter of the next); then compound 1; then compound 3.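

In this assay, ethyl in place of methoxy on a saturated chain carbon, two bonds along the chain from an aromatic carbon, is a large step (a number 51 percentage points lower from compound 3 to compound 4 (beyond the scatter)), so this single change in the chain can decide the outcome. Butyl also compares poorly with cyclopropyl (a number 29 percentage points lower from compound 1 to compound 4 (beyond the scatter)). With butyl present, 4-chlorophenyl and 2-chlorophenyl cannot be told apart (a number 2 percentage points lower from compound 2 to compound 4 (within the scatter)). On these data alone, whether a hydroxyl or an amine at this chain position would match methoxy remains open. No measured evidence explains the fall.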